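Swapping a methyl for oxetan-3-yl in compound 2

The source may report more compounds than this note shows. Statements on the series, on what has been measured and on what is new or still open speak of the compounds shown alone.

Compound 1 `COc1ccc(/C=C/C=C\c2cc(OC)c(OC)c(OC)c2)cc1O`: 118 nM
Compound 2 `COc1cc(-c2nnc3c(OC)cc(-c4ccc5[nH]ccc5c4)cn23)cc(OC)c1OC`: 167 nM

Both compounds were tested in a functional assay on A549 cells (Homo sapiens) for antiproliferative activity, read by MTT assay, with a stated time of 48 h; a higher number here means a weaker inhibitor, a lower number a stronger inhibitor. Compound 2, at 167 nM, lies within the usual scatter of compound 1, so the two values cannot be told apart. Compound 3 `COc1cc(-c2nnc3c(OC4COC4)cc(-c4ccc5[nH]ccc5c4)cn23)cc(OC)c1OC` keeps the core of compound 2 and has one change: oxetan-3-yl in place of methyl on an oxygen on an aromatic ring. The same difference can be read as methoxy to (oxetan-3-yl)oxy. Among the compounds with values here, no measured pair here shows what such a swap does, so any forecast is uncertain and starts from the value of compound 2. A modest move towards weaker inhibition is expected, and the estimated change is a 1.8-fold higher number from compound 2 to compound 3 (0.25 log units; within the scatter). For compound 3 the expected value is 300 nM, with an estimated range of 90 nM to 1000 nM.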

Compound 3, half-maximal inhibitory concentration: 9810 nM
The estimate for compound 3 lay 33-fold (1.51 log units) below the measured number; measured number above the stated range.
By their numbers in this assay, from the lowest: compounds 1 and 2 (each within the scatter of the next); then compound 3.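

In this assay, placing oxetan-3-yl instead of methyl on this oxygen gives a 59-fold higher number from compound 2 to compound 3 (1.77 log units; beyond the scatter), a large step and well beyond the scatter. This position is therefore not indifferent to what the oxygen carries: with the rest of compound 2 unchanged, this one swap is enough to lose most of the activity. Nothing in the data at hand explains the size of this loss.

A single swap cannot show whether other groups on this oxygen would behave in the same way. An ethyl group, or a cyclobutyl ring that keeps the four-membered ring but has no oxygen in it, would help show whether the loss follows the ring itself, the oxygen within it, or simply any group other than methyl.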